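Compound 4 and the anilide series: an expected value

A few compounds are considered here, and "the series" means these few. Any claim that something is new, unique, unknown or untested is made for them only; others in the source may bear on it.

Three compounds of one shared core have been examined in a functional assay on HCT-116 cells (Homo sapiens) for cytotoxicity, read by MTT assay, with a stated time of 48 h; a lower number here means a stronger inhibitor, a higher number a weaker inhibitor. Compound 1 `O=C(/C=C\Nc1ccc(F)cc1)c1nc(-c2ccc(F)cc2)n2ccccc12` reaches only the limit of the assay, > 30000 nM, and gives no number. Compound 3 `COc1ccc(N/C=C\C(=O)c2nc(-c3ccc(F)cc3)n3ccccc23)cc1OC` likewise stops at the limit, > 30000 nM, which is why the step that the two limits leave unreadable from compound 1 to compound 3 cannot be read; both sit at the limit of > 30000 nM in this assay, at which 2 of the 3 values shown sit. Compound 2 `O=C(/C=C\Nc1ccc(Cl)cc1)c1nc(-c2ccc(C(F)(F)F)cc2)n2ccccc12` alone yields a number in this assay, 11500 nM.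

Compound 4 `O=C(/C=C\Nc1ccc(Cl)cc1)c1nc(-c2ccc(F)cc2)n2ccccc12` has not been measured. It differs from compound 3 by 4-chlorophenyl in place of 3,4-dimethoxyphenyl on an amine nitrogen. Going by the values given here, no measured step between two numbers touches this change, so nothing can be said about its size. Among the compounds with values here, compound 4 shares the 4-chlorophenyl on the amine nitrogen with compound 2 and the 4-fluorophenyl of compound 1 and compound 3, yet no step between those pairs is readable, and the two limits give only a floor.

Compound 4 is therefore expected to land near the weak end of this assay, estimated at 20000 nM with a range from 8000 nM to 60000 nM, and the step of an at least 1.5-fold lower number from compound 3 to compound 4 (0.17 log units; that floor lies within the scatter) is expected to remain unreadable if the limit is again reported.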

Compound 4, half-maximal inhibitory concentration: 1210 nM
For compound 4 the middle estimate is 17-fold (1.22 log units) above the measured one; the whole stated range lies above it.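

Compound 4 shows that the group on the amine nitrogen can carry a large part of the result in this assay: 4-chlorophenyl in place of 3,4-dimethoxyphenyl gives an at least 24-fold lower number from compound 3 to compound 4 (1.39 log units; beyond the scatter), and chloro in place of fluoro on an aromatic carbon gives an at least 24-fold lower number from compound 1 to compound 4 (1.39 log units; beyond the scatter). Going by these compounds alone, these two steps are floors rather than exact sizes, since compound 1 and compound 3 each stand at a limit of the assay: the limit of > 30000 nM in this assay, at which 2 of the 4 values shown sit. With 4-chlorophenyl held on the amine nitrogen, the other aromatic substituent also counts, as fluoro in place of trifluoromethyl on an aromatic carbon gives a 9.5-fold lower number from compound 2 to compound 4 (0.98 log units; beyond the scatter), the only one of these steps with a number at both ends.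

Going by these compounds, what a bromo, a methyl or a nitrile would give in place of chloro on the phenyl at the amine nitrogen remains open. On these data alone, it is also open whether a chloro in place of the fluoro on the other aromatic ring would extend this step or reverse it.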